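Fluorine Returns to the Seven-Membered Ring

The source may report more compounds than this note shows. Statements on the series, on what has been measured and on what is new or still open speak of the compounds shown alone.

Measured compounds:
compound 1, `O=C(NC1CC1)c1ccc(CN([C@@H]2CC(F)(F)CCNC2=O)S(=O)(=O)c2ccc(Cl)cc2)cc1`, 1.9 mL.min-1.g-1
compound 2, `CC1(C)CCNC(=O)[C@H](N(Cc2ccc(C(=O)NC3CC3)cc2)S(=O)(=O)c2ccc(Cl)cc2)C1`, 36 mL.min-1.g-1

Compound 1 and compound 2 share one core and differ only in the group on the sulfonamide nitrogen. In an in vitro ADME assay on microsomes (Homo sapiens) for pharmacokinetics (on this read-out higher numbers stand for fast clearance and lower numbers for slow clearance), compound 1 gives 1.9 mL.min-1.g-1, while compound 2 gives 36 mL.min-1.g-1. Among the compounds with values here, the step of a 19-fold higher number from compound 1 to compound 2 (1.28 log units; beyond the scatter) is large, and compound 2 thus stands highest of the two numbers in this assay, with compound 1 as its only neighbour.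

Compound 3, `O=C(NC1CC1)c1ccc(CN(C2CC(C(F)(F)F)CCNC2=O)S(=O)(=O)c2ccc(Cl)cc2)cc1`, is not yet measured. It differs from compound 2 as follows: 2-oxo-5-(trifluoromethyl)azepan-3-yl in place of 5,5-dimethyl-2-oxoazepan-3-yl on a sulfonamide nitrogen. Within the data shown here, the only step that bears on this change is the one from compound 1 to compound 2, in which fluorine left the ring and the number rose sharply; in compound 3 fluorine comes back, though as a trifluoromethyl group rather than as two fluorines on the ring. Compound 3 is therefore expected to give a lower number than compound 2, by roughly a 4.5-fold lower number from compound 2 to compound 3 (0.65 log units; beyond the scatter), without full certainty that it falls as far as compound 1. The estimate for compound 3 in this assay is 8 mL.min-1.g-1, with a range from 3 mL.min-1.g-1 to 25 mL.min-1.g-1.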

Compound 3, intrinsic clearance in microsomes: 19 mL.min-1.g-1
For compound 3 the middle estimate is 2.4-fold (0.38 log units) below the measured one, within the range that was stated.
By their numbers in this assay, from the lowest: compound 1; then compounds 3 and 2 (each within the scatter of the next).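

In this assay the change to 2-oxo-5-(trifluoromethyl)azepan-3-yl gives a 1.9-fold lower number from compound 2 to compound 3 (0.28 log units; within the scatter), so compound 3 cannot be told apart from compound 2 on this read-out, even though fluorine has returned to the group on the sulfonamide nitrogen. The comparison with the difluoro group gives a 10-fold higher number from compound 1 to compound 3 (1.00 log units; beyond the scatter), a step beyond the scatter, which shows that at this place the presence of fluorine in the group does not by itself bring the low number of compound 1; among the three compounds, only the 5,5-difluoro-2-oxoazepan-3-yl group stands apart. Nothing available explains why the two fluorinated groups differ.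

The compounds shown leave open how a single methyl group, a single fluorine or a hydroxyl group in place of the trifluoromethyl would read. They do not separate the kind of substituent from its arrangement on the ring. They also leave open whether each separate stereoisomer of compound 3 would read alike, as its group carries no defined stereocentre while those of compound 1 and compound 2 do.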